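The compounds below may be only part of what the source reports. "The series", "measured", "known", "first", "only" and "open" are said of these compounds alone.

Within the data shown here, compound 2 `Cc1ccc(Nc2ncc3c(n2)N(C)C(=O)N(c2cc(NC(=O)c4cccc(C(F)(F)F)c4)ccc2C)C3)cc1N(C)C` holds one of only two numbers recorded in a functional assay on K562 cells (Homo sapiens) for antiproliferative activity, read by CellTiter-Glo and CCK-8 assay, with a stated time of 72 h (on this read-out lower numbers stand for stronger inhibition of growth and higher numbers for weaker inhibition of growth), where compound 2 gives 28 nM. Its nearest neighbour is compound 1 `Cc1ccc(Nc2ncc3c(n2)N(C)C(=O)N(c2cc(NC(=O)c4cccc(C(F)(F)F)c4)ccc2C)C3)cc1C`, which in this assay gives 17 nM; the step of a 1.6-fold higher number from compound 1 to compound 2 (0.22 log units; within the scatter) stays within the scatter, so neither compound can be ranked over the other. Compound 3 `Cc1ccc(Nc2ncc3c(n2)N(C)C(=O)N(c2cc(NC(=O)c4cccc(C(F)(F)F)c4)ccc2C)C3)cc1N` differs from compound 2 by amino in place of dimethylamino on an aromatic carbon. Among the measured compounds shown here, the only measured step that touches this place is the one just cited, and it was within the scatter, so for compound 3 the step of a 1.3-fold lower number from compound 2 to compound 3 (0.10 log units; within the scatter) is expected to stay within the scatter as well. Compound 3 is estimated at 22 nM, in a range from 8 nM to 60 nM.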

Compound 3, concentration for 50% growth inhibition: 3 nM
For compound 3 the middle estimate is 7.3-fold (0.87 log units) above the measured one; the measured number lies below the stated range.
By their numbers in this assay, from the lowest: compound 3; then compounds 1 and 2 (each within the scatter of the next).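

At this position, ortho to a methyl group, the choice of group matters after all: methyl and dimethylamino could not be told apart, but amino stands clearly apart from dimethylamino (a 9.3-fold lower number from compound 2 to compound 3 (0.97 log units; beyond the scatter)) and from methyl (a 5.7-fold lower number from compound 1 to compound 3 (0.75 log units; beyond the scatter)). Amino brings a hydrogen-bond donor where dimethylamino has none, though this is a count and not an explanation. Nothing measured here accounts for the difference.

The compounds shown leave open how a methylamino, hydroxyl or acetylamino group would read at this position. They also leave open whether amino would stand apart in the same way in a compound that differs elsewhere.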